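Shortening a Linker in a Purine-Based Antiproliferative Series

The compounds below may be only part of what the source reports. "The series", "measured", "known", "first", "only" and "open" are said of these compounds alone.

Compound 1 `Nc1ccccc1NC(=O)/C=C/c1ccc(Cn2cnc3c(Nc4cccc(OC(F)(F)F)c4)nc(Cl)nc32)cc1` and compound 3 `Nc1ccccc1NC(=O)c1ccc(Cn2cnc3c(Nc4cccc(OC(F)(F)F)c4)nc(Cl)nc32)cc1` share one core and differ in a single spot: (2-aminophenyl)carbamoyl in place of 2-((2-aminophenyl)carbamoyl)ethenyl on an aromatic carbon. In a functional assay on NCI-H460 cells (Homo sapiens) for antiproliferative activity, read by CCK-8 assay, with a stated time of 72 h, tested at 8 uM (a higher number here means a stronger effect of the compound at the concentration tested, a lower number a weaker effect), compound 1 gives 66.7%, and compound 3 gives 62.4%. The step is small: a number 4.3 percentage points lower from compound 1 to compound 3 (within the scatter), so this change left the read-out essentially where it was.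

Compound 2 `CCCCn1cnc2c(Nc3ccccc3)nc(NCOCc3ccc(/C=C/C(=O)Nc4ccccc4N)cc3)nc21` is built on a different core; how its core differs from that of compound 1 is not broken down here. In this assay compound 2 gives 34.2%, the lowest of the three measured numbers, and the gap to each of the other two lies beyond the scatter.

Compound 4 `CCCCn1cnc2c(Nc3ccccc3)nc(NCOCc3ccc(C(=O)Nc4ccccc4N)cc3)nc21` has not yet been measured. It is related to compound 2 in the same way that compound 3 is related to compound 1: (2-aminophenyl)carbamoyl in place of 2-((2-aminophenyl)carbamoyl)ethenyl on an aromatic carbon. The spot where the change is made is described in the same words for both pairs.

Going by the values given here, the only guide for what to expect is the measured pair. There the change made a step that was within the scatter, a number 4.3 percentage points lower from compound 1 to compound 3 (within the scatter), so on the different core of compound 2 the expectation is a similarly small step, a number 3.2 percentage points lower from compound 2 to compound 4 (within the scatter), with no good reason to expect a larger move in either direction. Compound 4 is therefore estimated at 31% in this assay, with a plausible range from 18% to 45%.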

Compound 4, a percentage reported as inhibition, at one concentration (the size of the read-out at that concentration, not a potency): 51.3%
Compound 4: the middle estimate sits 20.3 percentage points below what was measured, outside the stated range (above it).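

In this assay, putting (2-aminophenyl)carbamoyl in place of 2-((2-aminophenyl)carbamoyl)ethenyl on the core of compound 2 produced a clear move, a number 17.1 percentage points higher from compound 2 to compound 4 (beyond the scatter), whereas the same change on the core of compound 1 left the read-out essentially where it was. The change therefore does not carry over from one core to another with a fixed size in this series, and the core it is made on matters, as the two steps set side by side show: the same change on two cores in this assay, a number 4.3 percentage points lower (within the scatter) from compound 1 to compound 3 and a number 17.1 percentage points higher (beyond the scatter) from compound 2 to compound 4, 21.4 percentage points apart, beyond the scatter of two such steps. Going by these compounds alone, this rests on only two pairs and one read-out at a single concentration, so it does not show which part of the core is responsible, why the two cores respond differently, or how the change would behave on any third core.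

The compounds shown leave open what a longer chain between the aromatic ring and the (2-aminophenyl)carbamoyl amide would do on either core. They also leave open whether a hydroxamic acid in place of the 2-aminophenyl amide would follow the same core-dependent pattern.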